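This account rests on a few compounds, and the source may have more. Where it says the series, first, only, none or still open, it means among the compounds named here.

Working notes on the series. Compound 1 `O=C1NC[C@@H](c2c[nH]c3cc(Br)ccc23)N=C1c1c[nH]c2ccccc12` and compound 2 `O=C1NC[C@@H](c2c[nH]c3ccccc23)N=C1c1c[nH]c2ccccc12` share one core; compound 3 `O=C(C1=NC(c2c[nH]c3ccccc23)CN1)c1c[nH]c2cc(Br)ccc12` and compound 4 `O=C(C1=NC(c2c[nH]c3cc(Br)ccc23)CN1)c1c[nH]c2cc(Br)ccc12` share another, and the difference between the two cores is not broken down here. In an ADME assay on HCT-15 cells (Homo sapiens) for cytotoxicity (on this read-out lower numbers stand for an effect already at smaller amounts and higher numbers for an effect only at larger amounts of compound), compound 2 gives 4.79 ug/mL. In this assay compound 1 gives 4.2 ug/mL. The change bromo in place of hydrogen on an aromatic carbon thus produced a 1.1-fold lower number from compound 2 to compound 1 (0.06 log units; within the scatter). For compound 3 this assay returned only a limit, > 30 ug/mL, which is the limit of > 30 ug/mL in this assay, at which 1 of the 3 values shown sits. Compound 4 arises from compound 3 by the same change, (bromo in place of hydrogen on an aromatic carbon), at a place described in the same words. Compound 4 is expected to show a step that the limit leaves unreadable from compound 3 to compound 4, because a 1.1-fold lower number from compound 2 to compound 1 (0.06 log units; within the scatter) stayed within the scatter and compound 3 itself sits at a limit. The estimate for compound 4 is 35 ug/mL, between 15 ug/mL and 90 ug/mL, with a limit rather than a number the most likely outcome.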

Compound 4, concentration for half-maximal effect: 4.88 ug/mL
Compound 4: middle estimate off by 7.2-fold (0.86 log units), on the high side, outside the stated range (below it).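

In this assay, bromo in place of hydrogen on an aromatic carbon gives an at least 6.1-fold lower number from compound 3 to compound 4 (0.78 log units; beyond the scatter), so the size of the step does not carry over from one core to the other: the same change on two cores in this assay, a 1.1-fold lower number (0.06 log units; within the scatter) from compound 2 to compound 1 and an at least 6.1-fold lower number (0.78 log units; beyond the scatter) from compound 3 to compound 4, at least 5.3-fold (0.73 log units) apart, beyond the scatter of two such steps. Compound 3 stands at a limit, so the step on its core has a bound but no exact size: the limit of > 30 ug/mL in this assay, at which 1 of the 4 values shown sits. The two cores give a single comparison, which does not show what in them sets the two steps apart.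

Open, from the compounds shown here alone, is whether chloro, methoxy or an amine on the same aromatic carbon would also give steps that differ between the two cores. Also open, going by these compounds, is whether a third core would follow either step.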